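The source may report more compounds than this note shows. Statements on the series, on what has been measured and on what is new or still open speak of the compounds shown alone.

Measured so far:
- compound 1 `CC(O)(C(=O)Nc1ccc(S(=O)(=O)c2ccccc2F)cc1)C(F)(F)F`: 1300 nM
- compound 2 `CC(O)(C(=O)Nc1ccc(S(=O)(=O)c2ccccc2)c([N+](=O)[O-])c1)C(F)(F)F`: in a functional assay (Cavia porcellus) with sulfonylurea receptors; K-ATP channels (Homo sapiens) as the target (on this read-out higher numbers stand for weaker inhibition and lower numbers for stronger inhibition), compound 2 reaches only the assay limit, > 30000 nM, not a number.
- compound 3 `CC(O)(C(=O)Nc1ccc(C(=O)c2ccccc2)c(O)c1)C(F)(F)F`: 4200 nM

In this assay compound 1 holds the lowest of the two numbers that were obtained. Compound 3 stands at a higher number, and that gap lies beyond the scatter of repeated runs. Compound 2 gives no number at all; its result is a limit, (the limit of > 30000 nM in this assay, at which 1 of the 3 values shown sits), and nothing more is drawn from it here.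

Among the compounds with values here, no pair of measured compounds differs in just one place, so no single step has been sized.

Compound 4 `CC(O)(C(=O)Nc1ccc(S(=O)(=O)c2cccnc2)cc1)C(F)(F)F` remains to be measured. It is reached from compound 1 by one change: pyridin-3-yl in place of 2-fluorophenyl on a sulfonyl sulfur. Both groups sit on the sulfonyl sulfur of the shared core; the ring entering carries a hetero atom and one hydrogen-bond acceptor, where the leaving ring carried a fluorine and none. Within the data shown here, with no measured step of this kind to lean on, the expectation is a modest move, likely toward weaker inhibition, of roughly the size of the scatter, a 1.9-fold higher number from compound 1 to compound 4 (0.28 log units; within the scatter). Compound 4 is therefore estimated at 2500 nM in this assay, with a range from 800 nM to 8000 nM.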

Compound 4, half-maximal inhibitory concentration: 3500 nM
Beside the measured number, compound 4's estimate is 1.4-fold (0.15 log units) below it, within the range that was stated.
By their numbers in this assay, from the lowest: compound 1; then compounds 4 and 3 (each within the scatter of the next). At a limit, above all of these: compound 2.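

Pyridin-3-yl in place of 2-fluorophenyl on a sulfonyl sulfur is the first single change in this series whose size can be read: in this assay it gives a 2.7-fold higher number from compound 1 to compound 4 (0.43 log units; beyond the scatter). The group on the sulfonyl sulfur therefore matters to the read-out, though modestly, and a six-membered aromatic ring carrying a hetero atom and a hydrogen-bond acceptor still leaves a measurable number, with compound 4 at 3500 nM. Nothing measured in the series speaks to what lies behind this step.

The fluorine leaves and the ring nitrogen enters in the same step, so the share of each in the higher number stays unresolved, and a single step gives no trend for this place. Also open, going by these compounds, is how this assay would respond to a non-aromatic group on the sulfonyl sulfur, such as an amine or a short alkyl chain, or to a methoxy group or a chlorine in place of the fluorine on the phenyl ring.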